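The compounds below may be only part of what the source reports. "The series", "measured", "known", "first", "only" and "open" are said of these compounds alone.

Measured compounds in a functional assay on cells (leukaemia cell line, Homo sapiens) for inhibition, read by sulforhodamine B assay, with a stated time of 48 h; on this read-out higher numbers stand for weaker inhibition of growth and lower numbers for stronger inhibition of growth:
compound 1 `O=S(=O)(Nc1ccc(Cl)c(Cl)c1)c1ccc(-c2cnc(C3CC3)o2)cc1` gives 416 nM
compound 2 `O=S(=O)(Nc1ccc(Cl)c(F)c1)c1ccc(-c2cnc(C3CC3)o2)cc1` gives 380 nM
compound 3 `Cc1cc(NS(=O)(=O)c2ccc(-c3cnc(C4CC4)o3)cc2)ccc1Cl` gives 216 nM

Compound 3 gives the lowest of the three numbers, but its steps to the others are small: a 1.9-fold lower number from compound 1 to compound 3 (0.28 log units; within the scatter) and a 1.8-fold lower number from compound 2 to compound 3 (0.25 log units; within the scatter). Both lie within the scatter, so the three measured compounds cannot be placed in any order on these data.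

Compound 4 `O=S(=O)(Nc1ccc(F)cc1F)c1ccc(-c2cnc(C3CC3)o2)cc1` has not yet been measured in this assay. It differs from compound 3 by 2,4-difluorophenyl in place of 4-chloro-3-methylphenyl on a sulfonamide nitrogen. The measured steps that bear on this change are the three among compounds 1, 2 and 3: a 1.1-fold lower number from compound 1 to compound 2 (0.04 log units; within the scatter) shows that fluoro in place of chloro on an aromatic carbon leaves the number essentially unchanged, while a 1.9-fold lower number from compound 1 to compound 3 (0.28 log units; within the scatter) and a 1.8-fold lower number from compound 2 to compound 3 (0.25 log units; within the scatter) show that methyl in place of a halogen gives a somewhat lower number, still within the scatter. The 2,4-difluorophenyl of compound 4 carries no methyl, so a small step back toward the numbers of compounds 1 and 2 is expected in this assay. The expected step of a 2.3-fold higher number from compound 3 to compound 4 (0.36 log units; beyond the scatter) is small and may not exceed the scatter. Compound 4 is therefore estimated at 500 nM, with a range of 250 nM to 1000 nM.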

Compound 4, concentration for 50% growth inhibition: 356 nM
Compound 4: middle estimate off by 1.4-fold (0.15 log units), on the high side; the measured number falls inside the stated range.
By their numbers in this assay, from the lowest: compounds 3, 4, 2 and 1 (each within the scatter of the next).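

In this assay, for the compounds shown here, the change to 2,4-difluorophenyl on a sulfonamide nitrogen gives a 1.6-fold higher number from compound 3 to compound 4 (0.22 log units; within the scatter) and a 1.1-fold lower number from compound 2 to compound 4 (0.03 log units; within the scatter) and a 1.2-fold lower number from compound 1 to compound 4 (0.07 log units; within the scatter) so all three steps stay as small as those among the earlier compounds. Compounds 1, 2 and 3 all carry a chloro group on this aryl ring and compound 4 carries none, so on these four compounds a chloro group on this ring is not needed to keep the number within the scatter of the others. No measurement at hand offers an explanation for this flat result.

All four compounds carry a substituted phenyl on the sulfonamide nitrogen, so this position has yet to show a step beyond the scatter. Open, going by these compounds, is whether a pyridyl ring, a plain phenyl, or a phenyl bearing an amine or a carboxylic acid would give such a step.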